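Sulfonamide series: aryl swap on the sulfonamide nitrogen

A few compounds are considered here, and "the series" means these few. Any claim that something is new, unique, unknown or untested is made for them only; others in the source may bear on it.

Measured so far:
compound 1, `COc1ccc(NS(=O)(=O)c2ccc(N3CCNC3=O)cc2)cc1`: > 1000 nM
compound 2, `O=C1NCCN1c1ccc(S(=O)(=O)Nc2cccc(Oc3ccccc3)c2)cc1`: 220 nM

Compound 1 carries a 4-methoxyphenyl on the sulfonamide nitrogen. In a functional assay on MCF7 cells (Homo sapiens) for antiproliferative activity, read by sulforhodamine B assay, with a stated time of 48 h (a higher number here means a weaker inhibitor, a lower number a stronger inhibitor), compound 1 returns only a limit, > 1000 nM, so no number is fixed for it. Compound 2, with a 3-phenoxyphenyl in the same place, gives 220 nM in this assay, a value at which a number was reached. For the measured compounds named here, no step between two measured compounds is available in this set; the only fact on compound 1 is the limit of > 1000 nM in this assay, at which 1 of the 2 values shown sits.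

Compound 3, `Cc1ccc(C)c(NS(=O)(=O)c2ccc(N3CCNC3=O)cc2)c1`, has not been measured in this assay. It differs from compound 1 by 2,5-dimethylphenyl in place of 4-methoxyphenyl on a sulfonamide nitrogen, and compound 1 stands at a limit in this assay.

With compound 1 at a limit, the expected step from compound 1 to compound 3 cannot be read from a measured pair; the expectation is that a step that the limit leaves unreadable from compound 1 to compound 3 stays within the scatter, with no direction assigned. Compound 3 is therefore expected to give about 1500 nM in this assay, estimated between 400 nM and 6000 nM, with a real chance that only a limit is returned again.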

Compound 3, half-maximal inhibitory concentration: 48 nM
Beside the measured number, compound 3's estimate is 31-fold (1.49 log units) above it, outside the stated range (below it).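

Replacing 4-methoxyphenyl with 2,5-dimethylphenyl on a sulfonamide nitrogen gives an at least 20-fold lower number from compound 1 to compound 3 (1.31 log units; beyond the scatter) in this assay, so this place on the series can move the read-out strongly even though the group that leaves and the group that enters have the same heavy-atom count and the same kind of ring. Compound 1 stands at a limit, so the size of this step is a bound and not a measured difference: the limit of > 1000 nM in this assay, at which 1 of the 3 values shown sits.

For the compounds shown here, a 3-phenoxyphenyl is also not the only group here that returns a number, as compound 2 gives 220 nM and compound 3 gives 48 nM, the latter with a single ring and no oxygen in the group.

The compounds shown do not separate the loss of the methoxy oxygen, with its hydrogen-bond acceptor, from the arrival of the two methyl groups, which happen together in one step. As far as these compounds go, how a 2,5-dichlorophenyl, or a phenyl ring bearing an amine or a carboxylic acid, would stand in this assay also remains open.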